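Removing the Methyl From the Aromatic Ring of Compound 1

The source may hold more compounds than are shown below. What is called first, only, known or untested is meant among the compounds shown, and "the series" means these compounds.

Going by the values given here, compound 1 `Cc1c(CO)c(CO)c2n1[C@@H](c1ccccc1)SC2` holds the lowest of the two numbers measured so far in a functional assay on MCF7 cells (Homo sapiens) for cytotoxicity, read by MTT assay, with a stated time of 24 h (a higher number here means a weaker inhibitor, a lower number a stronger inhibitor), where compound 1 gives 12200 nM. Among the compounds with values here, its nearest neighbour is compound 2 `Cc1c(CO)c(CO)c2n1CSC2`, which in this assay gives 37800 nM; the step of a 3.1-fold higher number from compound 1 to compound 2 (0.49 log units; beyond the scatter) is the only measured change in this set, and it concerns a phenyl on a saturated ring carbon, not the aromatic ring.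

Compound 3 `OCc1cn2c(c1CO)CS[C@@H]2c1ccccc1` differs from compound 1 in a single place: hydrogen in place of methyl on an aromatic carbon. Within the data shown here, no measured step touches this methyl, so the phenyl step gives no direct guide to what its loss will do. Both measured compounds keep this methyl, and nothing in the data separates compounds with it from compounds without it. In this assay the expected change from compound 1 to compound 3 is therefore small, a 1.2-fold higher number from compound 1 to compound 3 (0.09 log units; within the scatter), and no direction can be argued for with confidence. Compound 3 is expected to give about 15000 nM in this assay, within a range from 6000 nM to 40000 nM.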

Compound 3, half-maximal inhibitory concentration: 70800 nM
Estimate against measurement, compound 3: 4.7-fold (0.67 log units) below; the whole stated range lies below it.
By their numbers in this assay, from the lowest: compound 1; then compounds 2 and 3 (each within the scatter of the next).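

In this assay the methyl next to the ring nitrogen proves to matter: exchanging it for hydrogen gives a 5.8-fold higher number from compound 1 to compound 3 (0.76 log units; beyond the scatter) and so makes for a weaker inhibitor, although only one carbon atom leaves and the rest of the molecule stays the same. Compound 1 now has two measured steps, the other being a 3.1-fold higher number from compound 1 to compound 2 (0.49 log units; beyond the scatter) for the change at the saturated ring carbon, and in this small set each of the two groups, methyl and phenyl, goes with a lower number when it is present. Nothing shown here gives a measured reason for the effect of the methyl.

From the compounds shown here alone, it remains open whether any carbon group on this aromatic carbon would serve as well as methyl, and an ethyl group, a longer chain or a chlorine atom in the same place would help to answer that. A compound with hydrogen at both places, in place of the methyl and the phenyl, would show whether the two steps add up or depend on each other.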